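The compounds below may be only part of what the source reports. "The series", "measured", "known", "first", "only" and "open" are said of these compounds alone.

In an assay on microsomes from liver (strain Wistar) for inhibition of acyl-CoA desaturase 1 (Rattus norvegicus), read by HPLC, with stated times of 1 h and 60 min (a higher number here means a weaker inhibitor, a lower number a stronger inhibitor), compound 2 `NC(=O)Nc1cnc(N2CCC(Oc3ccccc3C(F)(F)F)CC2)s1` gives 150 nM, the higher of the two numbers at hand. Compound 1 `NC(=O)c1cnc(N2CCC(Sc3ccccc3C(F)(F)F)CC2)s1` gives 4 nM in this assay, but the two differ in more than one place, so only the two values themselves can be set side by side. Compound 3 `OCc1nc(-c2cnc(N3CCC(Oc4ccccc4C(F)(F)F)CC3)s2)no1` carries 5-(hydroxymethyl)-1,2,4-oxadiazol-3-yl in place of ureido on an aromatic carbon. Among the compounds with values here, with no single-change step available, the change is expected to bring a modest shift toward a lower number, a 3.0-fold lower number from compound 2 to compound 3 (0.48 log units; beyond the scatter), though a result within the scatter would not surprise. Compound 3 is therefore estimated at 50 nM, with a range of 10 nM to 250 nM.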

Compound 3, half-maximal inhibitory concentration: 1 nM
Beside the measured number, compound 3's estimate is 50-fold (1.70 log units) above it; measured number outside the range, below it.
By their numbers in this assay, from the lowest: compound 3; then compound 1; then compound 2.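

In this assay the step to 5-(hydroxymethyl)-1,2,4-oxadiazol-3-yl in place of ureido is a 150-fold lower number from compound 2 to compound 3 (2.18 log units; beyond the scatter) and lies beyond the scatter. It shows that this aromatic carbon, next to the ring sulfur, can carry a five-membered aromatic ring instead of the open ureido group with a large gain in this read-out. Nothing measured here bears on why the step is so large. As far as these compounds go, how much of the step belongs to the hydroxymethyl and how much to the ring stays open. So does what a 5-methyl-1,2,4-oxadiazol-3-yl group or an amine would give at this position.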